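A second methoxy group on the ketone-side ring

The compounds below may be only part of what the source reports. "The series", "measured", "known", "first", "only" and "open" are said of these compounds alone.

Compound 1, `COc1ccc(-c2cc(/C=C/C(=O)c3ccc(C)cc3)nc3cc(-c4ccccc4)nn23)cc1OC`, gives 17200 nM in a functional assay on A549 cells (Homo sapiens) for antiproliferative activity, read by MTT assay, with a stated time of 24 h; on this read-out lower numbers stand for stronger inhibition and higher numbers for weaker inhibition.
Compound 2, `COc1ccc(C(=O)/C=C/c2cc(-c3ccc(OC)c(OC)c3)n3nc(-c4ccccc4)cc3n2)cc1`, gives 11900 nM in this assay.

Going by the values given here, compound 2 stands at the lower of the two numbers measured so far, with compound 1 nearest to it; the step of a 1.4-fold lower number from compound 1 to compound 2 (0.16 log units; within the scatter) separates them, and it is within the scatter, so the two compounds cannot be ranked against each other.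

Compound 3, `COc1ccc(C(=O)/C=C/c2cc(-c3ccc(OC)c(OC)c3)n3nc(-c4ccccc4)cc3n2)cc1OC`, differs from compound 2 in one place: methoxy in place of hydrogen on an aromatic carbon. Among the compounds with values here, the only measured step, a 1.4-fold lower number from compound 1 to compound 2 (0.16 log units; within the scatter), also concerns a methoxy group on an aromatic carbon, but there a methyl was replaced; no measured step adds a methoxy where only a hydrogen stood. That step stayed within the scatter, which gives little reason to expect a large move here. In this assay the step from compound 2 to compound 3 is expected to be small, a 1.2-fold lower number from compound 2 to compound 3 (0.08 log units; within the scatter), within the scatter. Compound 3 is therefore estimated at 10000 nM, in a range from 4500 nM to 22000 nM.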

Compound 3, half-maximal inhibitory concentration: 3900 nM
The estimate for compound 3 lay 2.6-fold (0.41 log units) above the measured number; the measured number lies below the stated range.
By their numbers in this assay, from the lowest: compound 3; then compounds 2 and 1 (each within the scatter of the next).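

Adding a methoxy group to the carbonyl-bearing ring, turning 4-methoxyphenyl into 3,4-dimethoxyphenyl, gives a 3.1-fold lower number from compound 2 to compound 3 (0.48 log units; beyond the scatter) in this assay and so produces the first change in this short series that stands clear of the usual variation between repeats. The earlier exchange of methyl for methoxy on the same ring, a 1.4-fold lower number from compound 1 to compound 2 (0.16 log units; within the scatter), could not separate the two compounds, whereas the full change from 4-methylphenyl to 3,4-dimethoxyphenyl gives a 4.4-fold lower number from compound 1 to compound 3 (0.64 log units; beyond the scatter); the aromatic carbon ortho to a methoxy group is therefore a place where a group of only two heavy atoms shifts the number measurably, although the shift is modest and compound 3 still sits in the micromolar range. No supporting measurement is available to explain why this added methoxy group lowers the number.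

The compounds shown leave open whether this shift belongs to the methoxy group itself or would also follow from a hydroxyl group, a fluorine atom or an amine on the same carbon. They also leave open what a longer chain, such as ethoxy, would do there.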